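Amide aryl variation in a urotensin-2 receptor series

The compounds below may be only part of what the source reports. "The series", "measured", "known", "first", "only" and "open" are said of these compounds alone.

Measured so far:
compound 1 `Cc1cc(C(=O)N[C@H]2CCN(Cc3ccc(OCCCN(C)C)cc3)C2)ccc1Br`: 631 nM
compound 2 `CN(C)CCCOc1ccc(CN2CC[C@H](NC(=O)c3ccc(-c4ccccc4)cc3)C2)cc1`: < 10000 nM

In an assay on HEK293 cells for binding affinity to Urotensin-2 receptor (Homo sapiens), read by radioligand binding (a lower number here means a stronger inhibitor, a higher number a weaker inhibitor), compound 1 gives 631 nM, the only number shown in the series. Compound 2 returns only a limit of this assay, < 10000 nM, and is not a number. Compound 3 `CN(C)CCCOc1ccc(CN2CC[C@H](NC(=O)c3ccco3)C2)cc1` carries furan-2-yl in place of 4-bromo-3-methylphenyl on a carbonyl carbon. Among the measured compounds shown here, no measured step between such compounds exists. A move toward weaker binding beyond the scatter is expected, a 4.8-fold higher number from compound 1 to compound 3 (0.68 log units; beyond the scatter). Compound 3 is estimated at 3000 nM, between 800 nM and 10000 nM, with a real chance of a limit as for compound 2.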

Compound 3, inhibition constant: < 10000 nM
Compound 3 gave a limit, no number (the forecaster's own chance of this, stated with the estimate: 35%); the middle value is on the limit's open side.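

Among the compounds shown here, compound 3 gives < 10000 nM, a limit and not a number, so no step from compound 1 to compound 3 can be read. The compounds shown leave open how any group other than 4-bromo-3-methylphenyl on the carbonyl compares with compound 1.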